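Half-life notes on a chlorinated sulfonamide lactam series

This account rests on a few compounds, and the source may have more. Where it says the series, first, only, none or still open, it means among the compounds named here.

Measured compounds, an in vivo ADME assay on the whole organism (strain Sprague-Dawley) for metabolic stability, with Rattus norvegicus as the target; on this read-out higher numbers stand for a longer-lived compound and lower numbers for a shorter-lived compound:
- compound 1, `O=C1[C@@H](NS(=O)(=O)c2ccc3cc(Cl)ccc3c2)CCN1c1ccc2c(c1)CCNC2`, gives 11 h
- compound 2, `O=C1[C@@H](NS(=O)(=O)c2ccc3c(Cl)c[nH]c3c2)CCN1c1ccc2c(c1)CCNC2`, gives 6.3 h
- compound 3, `O=C1[C@@H](NS(=O)(=O)c2ccc3c(Cl)c[nH]c3c2)CCN1c1ccc2c(c1F)CCNC2`, gives 7.8 h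

Compound 2 and compound 3 differ by one change, (fluoro in place of hydrogen on an aromatic carbon); the step is a 1.2-fold higher number from compound 2 to compound 3 (0.09 log units; within the scatter). The difference between the cores of compound 1 and compound 2 is not broken down here; their two values lie within the scatter of each other.

Compound 4, `O=C1[C@@H](NS(=O)(=O)c2ccc3cc(Cl)ccc3c2)CCN1c1cc2c(cc1F)CNCC2`, is not yet measured. It differs from compound 1 by fluoro in place of hydrogen on an aromatic carbon. This is the same kind of change as from compound 2 to compound 3, though not the same: there the place was ortho to a fused ring, ortho to a large group and meta to a fused ring; here it is ortho to a large group, meta to a fused ring and para to a fused ring. Because the earlier step of a 1.2-fold higher number from compound 2 to compound 3 (0.09 log units; within the scatter) stayed within the scatter, the step from compound 1 to compound 4 is expected to be small too, about a 1.1-fold higher number from compound 1 to compound 4 (0.04 log units; within the scatter). Compound 4 is therefore estimated at 12 h, between 7 h and 20 h.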

Compound 4, half-life: 7.5 h
Compound 4: middle estimate off by 1.6-fold (0.20 log units), on the high side; the measured number falls inside the stated range.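

In this assay, fluoro in place of hydrogen on an aromatic carbon gives a 1.5-fold lower number from compound 1 to compound 4 (0.17 log units; within the scatter). Set beside the earlier case, the two steps cannot be told apart: the same change on two cores in this assay, a 1.2-fold higher number (0.09 log units; within the scatter) from compound 2 to compound 3 and a 1.5-fold lower number (0.17 log units; within the scatter) from compound 1 to compound 4, 1.8-fold (0.26 log units) apart, within the scatter of two such steps. In these two pairs the change carries from one core to the other with no step beyond the scatter, but the place on the ring is not the same in the two pairs, and two pairs cannot show that the steps are equal or that the result holds on other cores.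

Still open, on these data alone, is what a trifluoromethyl, methoxy or nitrile group would give at the same aromatic carbon. As far as these compounds go, a methyl or acetyl group on the secondary amine also remains open.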